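A few compounds are considered here, and "the series" means these few. Any claim that something is new, unique, unknown or untested is made for them only; others in the source may bear on it.

Measured so far in an ADME assay on L6 cells (Rattus norvegicus) for cytotoxicity; on this read-out lower numbers stand for stronger inhibition and higher numbers for weaker inhibition:

compound 1, `O=C(NCCCN1CCN(CCCNc2ccnc3cc(Cl)ccc23)CC1)c1ccc(Oc2ccccc2)cc1`: 1400 nM
compound 2, `CC(=O)CCC(=O)NCCCN1CCN(CCCNc2ccnc3cc(Cl)ccc23)CC1`: 11000 nM
compound 3, `O=C(NCCCN1CCN(CCCNc2ccnc3cc(Cl)ccc23)CC1)c1ccccc1C(=O)c1ccccc1`: 3200 nM

Compound 2 stands at the highest of the three numbers, that is, the weakest inhibition, and its gap to compound 3 and to compound 1 lies beyond the scatter in both cases. The two compounds with an aromatic amide group sit at the lower end, compound 2 with its aliphatic group at the upper end.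

Compound 4, `O=C(NCCCN1CCN(CCCNc2ccnc3cc(Cl)ccc23)CC1)c1cc(Cl)cc(Cl)c1`, is not yet measured in this assay. It differs from compound 2 in one place: 3,5-dichlorophenyl in place of 2-acetylethyl on a carbonyl carbon. This puts compound 4 among the aromatic amides alongside compound 1 and compound 3.

Expected direction: a lower number than compound 2, beyond the scatter, because compound 1 gives 1400 nM and compound 3 gives 3200 nM in the same assay. The expected step is a 4.4-fold lower number from compound 2 to compound 4 (0.64 log units; beyond the scatter), a move toward the two aromatic amides. Compound 4 is estimated at 2500 nM, with a range from 900 nM to 7000 nM.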

Compound 4, half-maximal inhibitory concentration: 3000 nM
The estimate for compound 4 lay 1.2-fold (0.08 log units) below the measured number; low and high end bracket the measured number.
By their numbers in this assay, from the lowest: compound 1; then compounds 4 and 3 (each within the scatter of the next); then compound 2.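

For the compounds shown here, this is the first single-place comparison: in this assay, placing 3,5-dichlorophenyl instead of 2-acetylethyl on the carbonyl carbon gives a 3.7-fold lower number from compound 2 to compound 4 (0.56 log units; beyond the scatter), so the split between aliphatic and aromatic amide groups now rests on a direct step. The change removes the acetyl carbonyl and introduces the aromatic ring and both chlorine atoms together, so this single step cannot assign the shift to any one of these features. No measurement is available that bears on the reason for the shift.

As far as these compounds go, it remains open whether an unsubstituted phenyl group would give the same number as 3,5-dichlorophenyl. Also open, from the compounds shown here alone, is how a carboxylic acid, an amine or a longer alkyl chain would read at this carbonyl carbon.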